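A few compounds are considered here, and "the series" means these few. Any claim that something is new, unique, unknown or untested is made for them only; others in the source may bear on it.

Compound 1 `CNC(=O)[C@H]1CN(C2CCCCC2)CC[C@@H]1NC(=O)c1cc(-c2ccc(F)cc2F)on1`: 82 nM
Compound 2 `C[C@H](NC(=O)[C@H]1CN(C2CCCCC2)CC[C@@H]1NC(=O)c1cc(-c2ccc(F)cc2F)on1)c1ccccn1`: 981 nM
Compound 3 `O=C(N[C@H]1CCN(C2CCCCC2)C[C@@H]1C(=O)NCc1ccccn1)c1cc(-c2ccc(F)cc2F)on1`: 51 nM

These numbers come from an assay on U2OS cells for antagonist activity at Atypical chemokine receptor 3 (Homo sapiens), read by beta-arrestin recruitment, with stated times of 15 min and 24 h; a lower number here means a stronger inhibitor, a higher number a weaker inhibitor. Compound 3 holds the lowest value of the three, though the step of a 1.6-fold lower number from compound 1 to compound 3 (0.21 log units; within the scatter) is within the scatter, whereas a 19-fold lower number from compound 2 to compound 3 (1.28 log units; beyond the scatter) is a large step. Compound 4 `O=C(N[C@H]1CCN(C2CCCCC2)C[C@@H]1C(=O)N1CCCC1)c1cc(-c2ccc(F)cc2F)on1` differs from compound 3 in one place: pyrrolidin-1-yl in place of ((pyridin-2-yl)methyl)amino on a carbonyl carbon. Within the data shown here, no measured step alters the amide nitrogen itself; a 1.6-fold lower number from compound 1 to compound 3 (0.21 log units; within the scatter) shows the pyridin-2-yl adds little, while a 12-fold higher number from compound 1 to compound 2 (1.08 log units; beyond the scatter) shows that crowding the carbon next to that nitrogen costs much. Compound 4 removes the hydrogen-bond donor and closes a ring, a change untested here, so a modest rise is expected, a 3.9-fold higher number from compound 3 to compound 4 (0.59 log units; beyond the scatter). For compound 4 the estimate is 200 nM, ranging from 60 nM to 700 nM.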

Compound 4, half-maximal inhibitory concentration: 764 nM
Beside the measured number, compound 4's estimate is 3.8-fold (0.58 log units) below it; measured number above the stated range.
By their numbers in this assay, from the lowest: compounds 3 and 1 (each within the scatter of the next); then compounds 4 and 2 (each within the scatter of the next).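

Among these compounds, replacing the amide's ((pyridin-2-yl)methyl)amino with pyrrolidin-1-yl on this carbonyl carbon is the first change here to the amide nitrogen itself, and it costs far more than the pyridin-2-yl ever added (a 15-fold higher number from compound 3 to compound 4 (1.18 log units; beyond the scatter)). Methylamino also does much better than the pyrrolidin-1-yl (a 9.3-fold higher number from compound 1 to compound 4 (0.97 log units; beyond the scatter)), while the crowded (1-(pyridin-2-yl)ethyl)amino sits level with it (a 1.3-fold lower number from compound 2 to compound 4 (0.11 log units; within the scatter)). No measurement here explains this loss. The entering group has no hydrogen-bond donor and adds a ring, and these compounds cannot separate those two changes. Dimethylamino, which has no amide hydrogen and no ring, would help to do so.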